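Swapping the Fluorinated Aryl Group on Compound 2

A few compounds are considered here, and "the series" means these few. Any claim that something is new, unique, unknown or untested is made for them only; others in the source may bear on it.

Measured in a functional assay with Homo sapiens as the target; a lower number here means a stronger inhibitor, a higher number a weaker inhibitor:
Compound 1 `CC(C)[C@H](NC(=O)COc1cccc2ccccc12)C(=O)N[C@@H](CC(=O)O)C(=O)COc1ccc([N+](=O)[O-])cc1` gives 22800 nM
Compound 2 `CC(C)[C@H](NC(=O)COc1cccc2ccccc12)C(=O)N[C@@H](CC(=O)O)C(=O)COc1c(F)cccc1F` gives > 100000 nM
Compound 3 `CC(C)[C@H](NC(=O)COc1cccc2ccccc12)C(=O)N[C@@H](CC(=O)O)C(=O)COc1cc(F)c(F)cc1F` is still unmeasured

Compound 2 stands only at a limit of the assay, > 100000 nM. In compound 3, 2,4,5-trifluorophenyl sits in place of 2,6-difluorophenyl on an oxygen on a saturated carbon (2,4,5-trifluorophenyl in place of 2,6-difluorophenyl on an oxygen on a saturated carbon). Among the measured compounds shown here, the only measured step at this place is an at least 4.3-fold higher number from compound 1 to compound 2 (0.64 log units; beyond the scatter). For the measured compounds named here, that step is the sole guide, so a step of similar size towards a lower number in this assay is expected, though starting from a limit leaves its size uncertain. An estimated at least 2.8-fold lower number from compound 2 to compound 3 (0.45 log units; beyond the scatter) is expected. Compound 3 is expected at 35000 nM, within an estimated range of 7000 nM to 100000 nM.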

Compound 3, half-maximal inhibitory concentration: 16700 nM
Estimate against measurement, compound 3: 2.1-fold (0.32 log units) above; the range from low to high includes it.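

In this assay, the change on the oxygen gives an at least 5.9-fold lower number from compound 2 to compound 3 (0.77 log units; beyond the scatter), so a fluorinated phenyl at this place need not lie at the limit of the assay. Set against 4-nitrophenyl, 2,4,5-trifluorophenyl gives a 1.4-fold lower number from compound 1 to compound 3 (0.14 log units; within the scatter), so the two groups cannot be told apart here. The value of compound 2 is a limit, which makes the first step a bound only: the limit of > 100000 nM in this assay, at which 1 of the 3 values shown sits.

As far as these compounds go, whether the number of fluorines or their placement separates compound 2 from compound 3 stays open. Also open, from the compounds shown here alone, is how an amine or a carboxylic acid on this phenyl ring would read.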